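Replacing the amide-bearing ring in compound 3 with a methoxypyridine

This account rests on a few compounds, and the source may have more. Where it says the series, first, only, none or still open, it means among the compounds named here.

Within the data shown here, compound 3 `NC(=O)c1ccc(-c2cnc(C(=O)CCCCCCc3ccccc3)o2)cc1` is the strongest of the three compounds measured so far in an assay (Rattus norvegicus) for inhibition of Fatty-acid amide hydrolase 1 (Homo sapiens); on this read-out lower numbers stand for stronger inhibition and higher numbers for weaker inhibition: compound 3 gives 10 nM, while compound 2 `O=C(O)c1ccc(-c2cnc(C(=O)CCCCCCc3ccccc3)o2)cc1` gives 60 nM and compound 1 `Nc1ccccc1-c1cnc(C(=O)CCCCCCc2ccccc2)o1` gives 750 nM. The steps among them were all large: a 13-fold lower number from compound 1 to compound 2 (1.10 log units; beyond the scatter), a 75-fold lower number from compound 1 to compound 3 (1.88 log units; beyond the scatter) and a 6.0-fold lower number from compound 2 to compound 3 (0.78 log units; beyond the scatter).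

Compound 4 `COc1ccnc(-c2cnc(C(=O)CCCCCCc3ccccc3)o2)c1` changes the same part of the shared core: 4-methoxypyridin-2-yl in place of 4-carbamoylphenyl on an aromatic carbon. Among the measured compounds shown here, no measured step swaps the ring itself for a pyridine or adds a methoxy group, so only the general lesson applies: every change to this ring so far has moved the number well beyond the scatter, and the step from compound 2 to compound 3 shows that the amide group itself matters. Compound 4 gives up that amide and its hydrogen-bond donor, so a weaker result in this assay is expected, with a step of about a 6.0-fold higher number from compound 3 to compound 4 (0.78 log units; beyond the scatter). For compound 4 the estimate is 60 nM, expected to fall between 15 nM and 300 nM.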

Compound 4, inhibition constant: 0.8 nM
The estimate for compound 4 lay 75-fold (1.88 log units) above the measured number, and the stated range ends above it.
By their numbers in this assay, from the lowest: compound 4; then compound 3; then compound 2; then compound 1.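

In this assay, the change gives a 13-fold lower number from compound 3 to compound 4 (1.10 log units; beyond the scatter) and so shows that this position needs neither the amide hydrogen nor a carbon-only ring for a low number. The 4-methoxypyridin-2-yl group, with 0 hydrogen-bond donors, also gives a 75-fold lower number from compound 2 to compound 4 (1.88 log units; beyond the scatter) and a 940-fold lower number from compound 1 to compound 4 (2.97 log units; beyond the scatter) and places compound 4 lowest of the four compounds. No supporting measurement bears on why this swap lowers the number.

The swap brings in the ring nitrogen and the methoxy group together and removes the amide, so the compounds shown cannot assign the gain to any one of these changes. A plain pyridine ring and a methoxyphenyl group at this position would be the direct tests, each keeping only one of the two new features.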